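This account rests on a few compounds, and the source may have more. Where it says the series, first, only, none or still open, it means among the compounds named here.

Measured compounds in a functional assay on BT-549 cells (Homo sapiens) for inhibition, read by sulforhodamine B assay, with a stated time of 48 h; on this read-out lower numbers stand for higher toxicity in this test and higher numbers for lower toxicity in this test:

Compound 1, `COc1ccc(-c2cc(/C=C/C(=O)c3ccc(N)cc3)[nH]n2)cc1`, gives 36300 nM.
Compound 2, `COc1ccc(-c2cc(/C=C/C(=O)c3ccc(N)cc3)[nH]n2)cc1OC`, gives 5770 nM.
Compound 3, `COc1cc(C(=O)/C=C/c2cc(-c3cc(OC)c(OC)c(OC)c3)n[nH]2)cc(OC)c1OC`, gives 5600 nM.

Compound 2 and compound 3 sit close together in this assay, within the usual scatter of each other, so nothing separates them. Compound 1, by contrast, returns a clearly higher number than compound 3.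

Compound 4, `COc1ccc(-c2cc(/C=C/C(=O)c3cc(OC)c(OC)c(OC)c3)[nH]n2)cc1OC`, has not yet been measured in this assay. It is derived from compound 3 by one change, (hydrogen in place of methoxy on an aromatic carbon). The difference between the cores of compound 2 and compound 3 is not broken down here.

The same kind of change has already been measured once: compound 1 is derived from compound 2 by hydrogen in place of methoxy on an aromatic carbon, and that step produced a 6.3-fold higher number from compound 2 to compound 1 (0.80 log units; beyond the scatter). The surroundings of the place are not identical, however. In the step from compound 3 to compound 4 the position is, in addition, meta to a methoxy group, which is not so in the step from compound 2 to compound 1, so the two changes are the same kind of change rather than the same change.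

Among the measured compounds shown here, on the strength of that single earlier step, compound 4 is expected to show a 5.0-fold higher number from compound 3 to compound 4 (0.70 log units; beyond the scatter) in this assay, because a 6.3-fold higher number from compound 2 to compound 1 (0.80 log units; beyond the scatter) is the only guide available. The estimate for compound 4 in this assay is therefore 28000 nM, expected to fall between 8000 nM and 90000 nM.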

Compound 4, concentration lethal to 50% of the cells: 6320 nM
For compound 4 the middle estimate is 4.4-fold (0.65 log units) above the measured one; the whole stated range lies above it.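

In this assay, putting hydrogen in place of a methoxy group on an aromatic carbon gives a 1.1-fold higher number from compound 3 to compound 4 (0.05 log units; within the scatter), so compound 3 and compound 4 cannot be told apart in this test. The same kind of change therefore does not carry over with the same size from one core to the other, and the earlier step cannot be used as a general rule for this series: the same change on two cores in this assay, a 6.3-fold higher number (0.80 log units; beyond the scatter) from compound 2 to compound 1 and a 1.1-fold higher number (0.05 log units; within the scatter) from compound 3 to compound 4, 5.6-fold (0.75 log units) apart, beyond the scatter of two such steps

Among the compounds shown here, this does not show what causes the difference, since it rests on only two pairs of compounds, whose cores differ in more than one place and whose changed methoxy groups have different surroundings, so no single feature can be singled out as deciding the outcome.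

The compounds shown leave open how the number would respond if a hydroxyl group, an ethoxy group or a chlorine atom stood in place of the methoxy group at the same aromatic carbon. They also leave open whether replacing any of the other methoxy groups of compound 4 with hydrogen would follow the step seen on either core.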